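Aromatic substituent change on the fused core: benzylsulfanyl to dimethylamino

A few compounds are considered here, and "the series" means these few. Any claim that something is new, unique, unknown or untested is made for them only; others in the source may bear on it.

Compound 1 `OC[C@H]1OC(n2cnc3c(SCc4ccccc4)nccc32)[C@H](O)[C@@H]1O` carries a benzylsulfanyl group on its fused core, and in a functional assay on EL4 cells (Mus musculus) for inhibition, tested at 100 uM (a lower number here means less inhibition, a higher number more inhibition at the concentration tested (going by the name of the read-out)), compound 1 gives 30%. Among the compounds with values here, this is the only number in the set; the other value shown is a limit (the limit of < 5% in this assay, at which 1 of the 2 values shown sits). Compound 2 `CN(C)c1nccc2c1ncn2[C@H]1C[C@H](O)[C@@H](CO)O1` carries a dimethylamino group on a different sugar, and in this assay compound 2 reaches only the limit of < 5%. Compound 3 `CN(C)c1nccc2c1ncn2C1O[C@H](CO)[C@@H](O)[C@H]1O` keeps the sugar of compound 1 and the dimethylamino group of compound 2. The change from compound 1 to compound 3 is dimethylamino in place of benzylsulfanyl on an aromatic carbon. Within the data shown here, no measured step in this assay covers this change; the values of compound 1 and compound 2 show that the dimethylamino member of the series gives only a limit while the benzylsulfanyl member gives a number, so the step of a number 20 percentage points lower from compound 1 to compound 3 (beyond the scatter) is expected to go downward by more than the scatter. On that basis compound 3 is estimated at 10%, in the range 0% to 25%, with a fair chance that only the limit is reported.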

Compound 3, a percentage reported as inhibition, at one concentration (the size of the read-out at that concentration, not a potency): 10%
Estimate against measurement, compound 3: no gap at the digits printed, and the stated range covers the measured number.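

In this assay, dimethylamino in place of benzylsulfanyl on the aromatic carbon next to the ring nitrogen now has a measured size: a number 20 percentage points lower from compound 1 to compound 3 (beyond the scatter). The substituent at this position therefore matters on the sugar of compound 1, yet compound 3 still gives a number, 10%, with no six-membered aromatic ring of carbon in the group. Compound 2, with dimethylamino on a different sugar, remains a limit of the assay and not a number: the limit of < 5% in this assay, at which 1 of the 3 values shown sits.

The shown compounds do not separate the contributions of the sulfur, the carbon ring and the size of the group to this step. A methylsulfanyl group would test the sulfur without the ring, while a benzylamino group would test the ring with nitrogen in place of sulfur.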